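Extending the Amide Side Chain of Compound 1

The compounds below may be only part of what the source reports. "The series", "measured", "known", "first", "only" and "open" are said of these compounds alone.

Compound 1 `C=C(C)C(=O)Nc1cc2c(N3CCc4ccccc43)ncnc2cc1OC`: 7320 nM
Compound 2 `C=C(C)C(=O)Nc1cc2c(N3CCc4ccccc43)ncnc2cc1O[C@@H]1CCOC1`: 16600 nM
Compound 3 `CC/C=C/C(=O)Nc1cc2c(N3CCCc4ccccc43)ncnc2cc1OC`: 5030 nM

In a functional assay on A549 cells (Homo sapiens) for antiproliferative activity, read by MTT assay, with a stated time of 72 h (on this read-out lower numbers stand for stronger inhibition and higher numbers for weaker inhibition), compound 1 gives the second highest of the three numbers; compound 3 sits within the scatter of it, while compound 2 lies beyond it, a 2.3-fold higher number from compound 1 to compound 2 (0.36 log units; beyond the scatter). Compound 4 `COc1cc2ncnc(N3CCc4ccccc43)c2cc1NC(=O)/C=C/CN1CCCC1` differs from compound 1 by 3-(pyrrolidin-1-yl)prop-1-en-1-yl in place of 1-methylethenyl on a carbonyl carbon. Among the measured compounds shown here, no measured step touches the amide end: the single-point step from compound 1 to compound 2 concerns the oxygen on the aromatic ring, and compound 3 differs from compound 1 in two places at once, so its value shows only that another unsaturated amide on a related core lands within the scatter of compound 1. Without an anchor, compound 4 is expected to give a modest move towards a lower number, a 1.8-fold lower number from compound 1 to compound 4 (0.26 log units; within the scatter). Compound 4 is therefore estimated at 4000 nM, between 1500 nM and 12000 nM.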

Compound 4, half-maximal inhibitory concentration: 1210 nM
Estimate against measurement, compound 4: 3.3-fold (0.52 log units) above; measured number outside the range, below it.
By their numbers in this assay, from the lowest: compound 4; then compounds 3 and 1 (each within the scatter of the next); then compound 2.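

In this assay, the amide end now has its first single-place step: a 6.0-fold lower number from compound 1 to compound 4 (0.78 log units; beyond the scatter), with 3-(pyrrolidin-1-yl)prop-1-en-1-yl in place of 1-methylethenyl on the carbonyl carbon. This position therefore accepts a longer group carrying a five-membered ring with one nitrogen, and the number falls rather than rises. Nothing at hand bears on the cause of this step.

Going by these compounds, it remains open whether a dimethylamino group or a morpholine in place of the pyrrolidine would give a similar number. Also open, on these data alone, is whether this side chain would act the same way alongside the oxolan-3-yl group of compound 2.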